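The source may hold more compounds than are shown below. What is called first, only, known or untested is meant among the compounds shown, and "the series" means these compounds.

Compound 1 `COc1cccc(NC(=O)CSc2nnc(-c3cc(OC)c(OC)c(OC)c3)n2N)c1` and compound 2 `COc1cc(-c2nnc(SCC(=O)NCc3ccc(Cl)cc3)n2N)cc(OC)c1OC` share one core and differ only in the group carried on the amide-type nitrogen. In a functional assay on HepG2 cells (Homo sapiens) for antiproliferative activity, read by MTT assay, with a stated time of 48 h (on this read-out higher numbers stand for weaker inhibition and lower numbers for stronger inhibition), compound 1 reaches only a limit, > 100000 nM. Compound 2 likewise gives only a limit in this assay, namely > 100000 nM. The change between them, 4-chlorobenzyl in place of 3-methoxyphenyl, is accordingly a step that the two limits leave unreadable from compound 1 to compound 2. Compound 2 therefore stands at the limit of > 100000 nM in this assay, at which 2 of the 2 values shown sit, and has no number of its own.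

Compound 3 `COc1ccc(CNC(=O)CSc2nnc(-c3cc(OC)c(OC)c(OC)c3)n2N)cc1OC` is the one still to be measured; it carries 3,4-dimethoxyphenyl in place of 4-chlorophenyl on a saturated chain carbon bound to an amide-type nitrogen. Going by the values given here, no measured step bears on this change in a readable way, since the only step recorded is unreadable and both values are limits, so neither a direction nor a size beyond the scatter can be drawn from them. The expected step is a number no higher from compound 2 to compound 3 (the limit leaves the size open), and a further limit is the most likely outcome. Compound 3 is estimated in this assay at 100000 nM, with a range from 30000 nM to 300000 nM.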

Compound 3, half-maximal inhibitory concentration: > 100000 nM
Compound 3: a limit, no number; the forecaster's own chance of this, stated with the estimate: 80%; the middle value sits exactly at the limit.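

Going by these compounds alone, compound 3 also gives only a limit in this assay and no number, so no step among compound 1, compound 2 and compound 3 can be read. The compounds shown leave open whether any group on the amide-type nitrogen of the shared core brings measurable inhibition in this assay at all.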